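A few compounds are considered here, and "the series" means these few. Any claim that something is new, unique, unknown or untested is made for them only; others in the source may bear on it.

Measured so far:
- compound 1 `COc1ccc(S(=O)(=O)N2CCc3cccc(-c4ccc(F)c(F)c4)c32)cc1`: 55.5 nM
- compound 2 `COc1ccc(S(=O)(=O)N2CCc3cccc(-c4ccc(F)cc4)c32)cc1`: 79 nM
- compound 3 `COc1ccc(S(=O)(=O)N2CCc3cccc(-c4c(F)c(F)c(F)c(F)c4F)c32)cc1`: 1780 nM

In a functional assay on MKN-45 cells (Homo sapiens) for inhibition, with a stated time of 72 h (a higher number here means a weaker inhibitor, a lower number a stronger inhibitor), compound 1 at 55.5 nM stands with compound 2 at the low end of the numbers, the two lying within the scatter of each other. For the measured compounds named here, compound 3 is far higher at 1780 nM, but it is not a single-place neighbour of compound 1 and gives no measured step here.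

The next compound is compound 4 `COc1ccc(S(=O)(=O)N2CCc3cccc(-c4ccccc4)c32)cc1`, with phenyl in place of 3,4-difluorophenyl on an aromatic carbon.

Going by the values given here, one measured step bears on this: a 1.4-fold higher number from compound 1 to compound 2 (0.15 log units; within the scatter), with hydrogen in place of fluoro on an aromatic carbon. That step takes away only part of the fluoro of compound 1, whereas the change to compound 4 takes away all of it. The data do not show how a second such replacement would behave.

In this assay the expected step is a 1.7-fold higher number from compound 1 to compound 4 (0.23 log units; within the scatter), a slightly higher number and nothing clearly beyond the scatter. For compound 4 the estimated value is 95 nM, with an expected range of 40 nM to 230 nM.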

Compound 4, half-maximal inhibitory concentration: 117 nM
Compound 4: middle estimate off by 1.2-fold (0.09 log units), on the low side; measured number inside the range.
By their numbers in this assay, from the lowest: compounds 1, 2 and 4 (each within the scatter of the next, the first and the last beyond it); then compound 3.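

In this assay, taking away both fluoro groups of the 3,4-difluorophenyl gives a 2.1-fold higher number from compound 1 to compound 4 (0.32 log units; beyond the scatter), a modest step but the only one at this position printed beyond the scatter. Each single replacement of fluoro by hydrogen stays within the scatter, with a 1.4-fold higher number from compound 1 to compound 2 (0.15 log units; within the scatter) and a 1.5-fold higher number from compound 2 to compound 4 (0.17 log units; within the scatter), so among these compounds only the two replacements together give a readable change. No measurement at hand accounts for the size of these steps.

Still open, from the compounds shown here alone, is how this position responds to a substituent other than fluoro, such as a nitrile, an amine or a carboxylic acid on the phenyl. Also open, going by these compounds, is whether any such group would move the number by more than the modest step seen here.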